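A few compounds are considered here, and "the series" means these few. Any claim that something is new, unique, unknown or untested is made for them only; others in the source may bear on it.

Measured compounds:
compound 1, `COc1cccc(/C=C2\CCC/C(=C\c3ccccc3Cl)C2=O)c1OC`: 44200 nM
compound 2, `COc1ccccc1/C=C1\CCC/C(=C\c2cccc(OC)c2OC)C1=O`: 31300 nM

In an ADME assay on NHDF cells (Homo sapiens) for cytotoxicity, read by MTT assay, with a stated time of 72 h (on this read-out lower numbers stand for stronger inhibition and higher numbers for weaker inhibition), compound 1 stands highest of the two numbers; its nearest neighbour is compound 2, with a 1.4-fold lower number from compound 1 to compound 2 (0.15 log units; within the scatter). Compound 3, `COc1cc(/C=C2\CCC/C(=C\c3cccc(OC)c3OC)C2=O)ccc1O`, is still unmeasured. It differs from compound 1 in one place: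
4-hydroxy-3-methoxyphenyl in place of 2-chlorophenyl on a double-bonded chain carbon bound to a double-bonded ring carbon
Within the data shown here, the only measured step, a 1.4-fold lower number from compound 1 to compound 2 (0.15 log units; within the scatter), also swaps out a chloro on an aromatic carbon, but puts a methoxy in its place and stays within the scatter. Nothing measured covers the 4-hydroxy-3-methoxyphenyl group itself, so the present change is read as a broader exchange of the same kind. The expectation is therefore a step of no more than the scatter in this assay, with a slight lean toward a lower number as in a 1.4-fold lower number from compound 1 to compound 2 (0.15 log units; within the scatter), giving an expected 1.3-fold lower number from compound 1 to compound 3 (0.10 log units; within the scatter). Compound 3 is estimated at 35000 nM, in the range 15000 nM to 80000 nM.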

Compound 3, half-maximal inhibitory concentration: 14300 nM
The estimate for compound 3 lay 2.4-fold (0.39 log units) above the measured number; measured number outside the range, below it.
By their numbers in this assay, from the lowest: compound 3; then compounds 2 and 1 (each within the scatter of the next).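

In this assay, the place on a double-bonded chain carbon bound to a double-bonded ring carbon now gives steps beyond the scatter: with 4-hydroxy-3-methoxyphenyl entering, there is a 3.1-fold lower number from compound 1 to compound 3 (0.49 log units; beyond the scatter), replacing 2-chlorophenyl, and a 2.2-fold lower number from compound 2 to compound 3 (0.34 log units; beyond the scatter), replacing 2-methoxyphenyl. The earlier exchange, a 1.4-fold lower number from compound 1 to compound 2 (0.15 log units; within the scatter), stayed within the scatter, so among these compounds only the entering 4-hydroxy-3-methoxyphenyl, with 1 hydrogen-bond donor and 2 hydrogen-bond acceptors where 2-chlorophenyl has none, moves the number beyond it. No available measurement explains the lower number for compound 3.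

The compounds shown do not separate the contribution of the hydroxy from that of the methoxy within the entering group. Also open, on these data alone, is how an amine or a carboxylic acid on the aromatic ring at this place would read in this assay.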